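Bromine for Chlorine on the Benzyl Ring of Compound 3

The source may hold more compounds than are shown below. What is called first, only, known or untested is meant among the compounds shown, and "the series" means these compounds.

Compound 1 `O=c1cc(O)c2ccc(OCc3cccc(Br)c3)cc2o1` — 490 nM
Compound 2 `NC(=O)COc1cc(=O)oc2cc(OCc3cccc(Br)c3)ccc12` — 8.91 nM
Compound 3 `O=c1cc(CCl)c2ccc(OCc3cccc(Cl)c3)cc2o1` — 43.7 nM

In an assay on isolated protein (strain Sprague-Dawley) for inhibition of Amine oxidase [flavin-containing] B (Rattus norvegicus), read by spectrophotometry, with a stated time of 5 min (a lower number here means a stronger inhibitor, a higher number a weaker inhibitor), compound 3 gives 43.7 nM, the second highest of the three numbers. Its nearest neighbour is compound 2, which gives 8.91 nM, and its furthest is compound 1, which gives 490 nM. Compound 4 `O=c1cc(CCl)c2ccc(OCc3cccc(Br)c3)cc2o1` differs from compound 3 by bromo in place of chloro on an aromatic carbon. Within the data shown here, the only measured step, a 55-fold lower number from compound 1 to compound 2 (1.74 log units; beyond the scatter), concerns a different position and does not bear on this halogen exchange; compound 1 and compound 3 differ in two places, so their gap is not a single step either. With no measured exchange of bromo for chloro, a step within the scatter is expected, a 1.5-fold lower number from compound 3 to compound 4 (0.16 log units; within the scatter). Compound 4 is therefore estimated at 30 nM, between 10 nM and 100 nM.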

Compound 4, half-maximal inhibitory concentration: 209 nM
Compound 4: middle estimate off by 7.0-fold (0.84 log units), on the low side; the measured number lies above the stated range.
By their numbers in this assay, from the lowest: compound 2; then compound 3; then compound 4; then compound 1.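

In this assay, the change from 3-chlorophenyl to 3-bromophenyl is not silent: it brings a 4.8-fold higher number from compound 3 to compound 4 (0.68 log units; beyond the scatter). With the 3-bromophenyl group held constant, compound 4 adds a third group to the series at the other varied site, with chloromethyl giving a 23-fold higher number from compound 2 to compound 4 (1.37 log units; beyond the scatter) against carbamoylmethoxy and a 2.3-fold lower number from compound 1 to compound 4 (0.37 log units; beyond the scatter) against hydroxy. The number there therefore rises from carbamoylmethoxy to chloromethyl, and is highest with hydroxy.

Nothing available accounts for the halogen step. Going by these compounds, whether that step recurs with carbamoylmethoxy in place of chloromethyl remains open, as does how a fluoro or methyl group on the benzyl ring, or an amine or carboxylic acid at the other site, would read.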